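Three Carboxylic Acids, One Shared Core, One Open Question

The compounds below may be only part of what the source reports. "The series", "measured", "known", "first", "only" and "open" are said of these compounds alone.

Compound 1 `O=C(O)C1C(C(=O)NCCCc2ccccc2)[C@H]2CC[C@@H]1O2` carries the shared core with a side chain that ends in a phenyl group. In an ADME assay on A-431 cells (Homo sapiens) for cytotoxicity, read by MTT assay, with a stated time of 72 h (on this read-out lower numbers stand for stronger inhibition of growth and higher numbers for weaker inhibition of growth), compound 1 gives 10000 nM. Two companions on the same core, compound 2 `O=C(O)c1ccc(NC(=O)C2C(C(=O)O)[C@@H]3CC[C@H]2O3)cc1Cl` and compound 3 `O=C(O)C1C(C(=O)Nc2ccc(CO)cc2)[C@H]2CC[C@@H]1O2`, each carry an aromatic group on the amide side; in this assay compound 2 gives 10000 nM, and in this assay compound 3 gives 10000 nM. Compound 1 thus stands level with compound 2 and with compound 3 at the digits shown, with no difference beyond the scatter in either direction.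

Compound 4 `O=C(O)CCCNC(=O)C1C(C(=O)O)[C@@H]2CC[C@H]1O2` has not yet been measured. The change from compound 1 is carboxy in place of phenyl on a saturated chain carbon, three bonds along the chain from an amide-type nitrogen. Among the compounds with values here, no single-change step between measured compounds is available to calibrate this move, so the expectation rests on the three values themselves. With compound 1, compound 2 and compound 3 all sitting at one value, the step from compound 1 to compound 4 is expected to be none beyond the scatter, no change at the digits printed from compound 1 to compound 4 (within the scatter). Compound 4 is therefore estimated at 10000 nM in this assay, with a range from 5000 nM to 20000 nM.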

Compound 4, concentration for 50% growth inhibition: 10000 nM
Estimate against measurement, compound 4: no gap at the digits printed; the measured number falls inside the stated range.
By their numbers in this assay, from the lowest: compounds 1, 2, 3 and 4 (each within the scatter of the next).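

In this assay, the swap of phenyl for carboxy on a saturated chain carbon, three bonds along the chain from an amide-type nitrogen, gives no change at the digits printed from compound 1 to compound 4 (within the scatter), and this is the only step shown here in which two compounds differ in just one place. The earlier compounds shown here could only be set side by side as differently built molecules, whereas this pair shows that at this one position, a six-membered aromatic ring of carbon only and a carboxy group, which has no ring and brings a hydrogen-bond donor and acceptor, give the same printed number. Nothing measured here offers an explanation for this result.

As far as these compounds go, all four compounds share one printed value, so it remains open whether any group at this chain end can move the number at all, for example an amine, a methyl ester or a longer chain carrying the same phenyl. Also open, from the compounds shown here alone, is what a change on the shared core would do, such as replacing its own carboxylic acid with a primary amide.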